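Methoxy in place of diethylamino on the shared core

The compounds below may be only part of what the source reports. "The series", "measured", "known", "first", "only" and "open" are said of these compounds alone.

Measured in a functional assay on DU-145 cells (Homo sapiens) for cytotoxicity, read by MTT assay, with a stated time of 72 h; on this read-out lower numbers stand for stronger inhibition and higher numbers for weaker inhibition:
- compound 1 `Nc1cc2nc(-c3ccccc3)nn(-c3ccccc3)c-2cc1=O`: 1830 nM
- compound 2 `CNc1cc2nc(-c3ccccc3)nn(-c3ccccc3)c-2cc1=O`: 980 nM
- compound 3 `CCN(CC)c1cc2nc(-c3ccccc3)nn(-c3ccccc3)c-2cc1=O`: 3110 nM

Compound 3 gives 3110 nM, at the upper end of the numbers shown. One step to it exceeds the scatter, a 3.2-fold higher number from compound 2 to compound 3 (0.50 log units; beyond the scatter), and the other does not, a 1.7-fold higher number from compound 1 to compound 3 (0.23 log units; within the scatter).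

The next change is methoxy in place of diethylamino on an aromatic carbon gives compound 4 `COc1cc2nc(-c3ccccc3)nn(-c3ccccc3)c-2cc1=O`. For the measured compounds named here, no measured compound carries methoxy, so the evidence is indirect. The measured steps only exchange one nitrogen substituent for another. They stay small, with a 1.9-fold lower number from compound 1 to compound 2 (0.27 log units; within the scatter) as the third of them, and the largest is the modest one ending at compound 3. A step of similar or smaller size is therefore expected in this assay, leaning to a lower number given the upper-end value of compound 3, 3110 nM. The expected change is a 1.7-fold lower number from compound 3 to compound 4 (0.24 log units; within the scatter). For compound 4 the estimated value is 1800 nM, with an expected range of 700 nM to 4500 nM.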

Compound 4, half-maximal inhibitory concentration: > 5000 nM
Compound 4 gave a limit, no number; the forecaster's own chance of this, stated with the estimate: 3%; middle value at least 2.7-fold (0.44 log units) from the limit.
By their numbers in this assay, from the lowest: compounds 2, 1 and 3 (each within the scatter of the next, the first and the last beyond it). At a limit, above all of these: compound 4.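

In this assay compound 4 gives > 5000 nM, a limit and not a number. Methoxy, the only group here joined through oxygen rather than nitrogen, gives steps beyond the scatter against the two smaller nitrogen groups at this aromatic carbon: an at least 2.7-fold higher number from compound 1 to compound 4 (0.43 log units; beyond the scatter) and an at least 5.1-fold higher number from compound 2 to compound 4 (0.70 log units; beyond the scatter). Against diethylamino the floor stays within the scatter, with an at least 1.6-fold higher number from compound 3 to compound 4 (0.20 log units; that floor lies within the scatter), so the full size of that step cannot be read: the limit of > 5000 nM in this assay, at which 1 of the 4 values shown sits.

From the compounds shown here alone, it remains open whether the higher number goes with the oxygen link in general or with methoxy alone. Ethoxy or a longer alkoxy chain, or a cyclic amine such as morpholine, at this aromatic carbon would help separate these two readings.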